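This account rests on a few compounds, and the source may have more. Where it says the series, first, only, none or still open, it means among the compounds named here.

Measured so far in a functional assay on A549 cells (Homo sapiens) for antiproliferative activity, read by MTT assay, with a stated time of 48 h; on this read-out lower numbers stand for stronger inhibition and higher numbers for weaker inhibition:
- Compound 1 `C/C(=C\CC/C(C)=C/CC[C@@H]1[C@@]2(C)CCC(=O)C(C)(C)[C@H]2CC[C@@]1(C)O)CC/C=C(\C)C(=O)OCc1cn(-c2ccc(F)cc2)nn1` gives > 150000 nM as a limit of the assay, not a number
- Compound 2 `C/C(=C\CC/C(C)=C/CC[C@@H]1[C@@]2(C)CCC(=O)C(C)(C)[C@H]2CC[C@@]1(C)O)CC/C=C(\C)C(=O)OCc1cn(C[C@@H]2O[C@H](n3ccc(=O)[nH]c3=O)C[C@H]2O)nn1` gives 28100 nM as a number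
- Compound 3 `C#CCOC(=O)/C(C)=C/CC/C(C)=C/CC/C(C)=C/CC[C@@H]1[C@@]2(C)CCC(=O)C(C)(C)[C@H]2CC[C@@]1(C)O` gives 45100 nM as a number

For the measured compounds named here, compound 3 lies within the scatter of compound 2, and these two hold the only actual numbers in the set. The next compound to be read in this assay is compound 4 `C/C(=C\CC/C(C)=C/CC[C@@H]1[C@@]2(C)CCC(=O)C(C)(C)[C@H]2CC[C@@]1(C)O)CC/C=C(\C)C(=O)OCc1cn(-c2ccccc2)nn1`. It carries 1-phenyl-1H-1,2,3-triazol-4-yl in place of ethynyl on a saturated chain carbon bound to an oxygen next to a carbonyl group.

Going by the values given here, one measured step bears on this change, and it runs the other way. With ethynyl in place of 1-(4-fluorophenyl)-1H-1,2,3-triazol-4-yl at the same place, the data show an at least 3.3-fold lower number from compound 1 to compound 3 (0.52 log units; beyond the scatter) as the result. The size of that step is only a minimum, since one of its ends is a limit. It is also a single pair, so no general pattern is claimed. Read in reverse, it leads to the expectation of a higher number for compound 4, meaning weaker inhibition, and a reading at the limit of the assay would not be surprising. The expected change is a 2.7-fold higher number from compound 3 to compound 4 (0.43 log units; beyond the scatter) in size. For compound 4 the estimated value is 120000 nM with an expected range from 55000 nM to 260000 nM in this assay.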

Compound 4, half-maximal inhibitory concentration: > 150000 nM
Compound 4: no number, only a limit (the forecaster's own chance of this, stated with the estimate: 50%); middle value at least 1.2-fold (0.09 log units) from the limit.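

In this assay, compound 4 gives > 150000 nM, which is a limit of the assay and not a number. Putting 1-phenyl-1H-1,2,3-triazol-4-yl in place of ethynyl on a saturated chain carbon bound to an oxygen next to a carbonyl group gives an at least 3.3-fold higher number from compound 3 to compound 4 (0.52 log units; beyond the scatter), so the loss of a readable number at this place also occurs without the fluoro group carried by compound 1. The effect of hydrogen in place of fluoro on an aromatic carbon, from compound 1 to compound 4, cannot be read, as both ends of that step are limits: the limit of > 150000 nM in this assay, at which 2 of the 4 values shown sit.

The compounds shown leave open how far past that limit compound 1 and compound 4 lie, so the true size of the step from the ethynyl compound remains a minimum. They also leave open whether an amine or a carboxylic acid on the phenyl ring of the 1-phenyl-1H-1,2,3-triazol-4-yl group, or a benzyl group in place of that phenyl, would bring the reading back to a number.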